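The source may hold more compounds than are shown below. What is called first, only, known or untested is meant among the compounds shown, and "the series" means these compounds.

Compound 1 `CC(C)Oc1ccccc1-c1cn(C)c(=O)c2[nH]c(C(=O)NCc3ccc(C(=O)Nc4ccccc4N)cc3)cc12`: 130 nM
Compound 2 `COc1cccc(-c2cn(C)c(=O)c3[nH]c(C(=O)NCc4ccc(C(=O)Nc5ccccc5N)cc4)cc23)c1`: 250 nM

In a functional assay on MV4-11 cells (Homo sapiens) for antiproliferative activity, read by CCK-8 assay, with a stated time of 72 h (on this read-out lower numbers stand for stronger inhibition and higher numbers for weaker inhibition), compound 2 gives 250 nM, which is within the scatter of compound 1, as a 1.9-fold higher number from compound 1 to compound 2 (0.28 log units; within the scatter) shows. Compound 3 `Cc1ccccc1-c1cn(C)c(=O)c2[nH]c(C(=O)NCc3ccc(C(=O)Nc4ccccc4N)cc3)cc12` carries 2-methylphenyl in place of 3-methoxyphenyl on an aromatic carbon of the shared core: 2-methylphenyl in place of 3-methoxyphenyl on an aromatic carbon. Among the compounds with values here, the only measured step bearing on this is a 1.9-fold higher number from compound 1 to compound 2 (0.28 log units; within the scatter), an exchange of group at that carbon, and it is small. The expected change is therefore none beyond the scatter, estimated as a 1.4-fold lower number from compound 2 to compound 3 (0.14 log units; within the scatter). For compound 3 the estimated value is 180 nM, with an expected range of 70 nM to 450 nM.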

Compound 3, half-maximal inhibitory concentration: 310 nM
Estimate against measurement, compound 3: 1.7-fold (0.24 log units) below, and the stated range covers the measured number.
By their numbers in this assay, from the lowest: compounds 1, 2 and 3 (each within the scatter of the next, the first and the last beyond it).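

In this assay, the exchange of group at this aromatic carbon stays within the scatter, with a 1.2-fold higher number from compound 2 to compound 3 (0.09 log units; within the scatter). Methyl in place of isopropoxy gives the first step in the series beyond the scatter, though a modest one, with a 2.4-fold higher number from compound 1 to compound 3 (0.38 log units; beyond the scatter), so the number does respond to the group on this phenyl. Nothing available accounts for either step.

Going by these compounds, it remains open whether an amine, a carboxylic acid or a chain longer than isopropoxy on this phenyl would move the number further, and in which direction.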